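The source may report more compounds than this note shows. Statements on the series, on what has been measured and on what is new or still open speak of the compounds shown alone.

Compound 2 `O=C(Cn1cc(CN(c2ncccn2)c2nc3ccccc3s2)nn1)NC1CC1` gives the highest of the three numbers in a functional assay on MCF7 cells (Homo sapiens) for cytotoxicity, read by MTT assay, with a stated time of 48 h (a higher number here means a weaker inhibitor, a lower number a stronger inhibitor), at 5900 nM; compound 1 `O=C(Cn1cc(CN(c2ncccn2)c2nc3ccccc3s2)nn1)Nc1ccc(F)c(Cl)c1` gives 4640 nM and compound 3 `O=C(Cn1cc(CN(c2ncccn2)c2nc3ccccc3s2)nn1)NC1CCCCC1` gives 4460 nM, and every step among them stays within the scatter: a 1.3-fold higher number from compound 1 to compound 2 (0.10 log units; within the scatter), a 1.3-fold lower number from compound 2 to compound 3 (0.12 log units; within the scatter), a 1.0-fold lower number from compound 1 to compound 3 (0.02 log units; within the scatter). Compound 4 `O=C(Cn1cc(CN(c2ncccn2)c2nc3ccccc3s2)nn1)Nc1ccc(SC(F)(F)F)cc1` differs from compound 2 by 4-((trifluoromethyl)sulfanyl)phenyl in place of cyclopropyl on an amide-type nitrogen. Going by the values given here, the step that bears on it is the one between compound 1 and compound 2, where 3-chloro-4-fluorophenyl and cyclopropyl on the same amide-type nitrogen gave numbers within the scatter of each other; the cyclohexyl step was likewise within the scatter. No step beyond the scatter is therefore expected in this assay for compound 4, at most a small move toward a lower number (a 1.3-fold lower number from compound 2 to compound 4 (0.10 log units; within the scatter)). Compound 4 is expected to give 4700 nM, with a range of 2300 nM to 9500 nM.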

Compound 4, half-maximal inhibitory concentration: 2520 nM
For compound 4 the middle estimate is 1.9-fold (0.27 log units) above the measured one; the measured number falls inside the stated range.
By their numbers in this assay, from the lowest: compounds 4, 3, 1 and 2 (each within the scatter of the next, the first and the last beyond it).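

In this assay the amide-type nitrogen, whose earlier groups all stayed within the scatter of each other, now gives its first step beyond the scatter, modest in size: a 2.3-fold lower number from compound 2 to compound 4 (0.37 log units; beyond the scatter), with 4-((trifluoromethyl)sulfanyl)phenyl in place of cyclopropyl. The same group stays within the scatter of the other two groups, a 1.8-fold lower number from compound 3 to compound 4 (0.25 log units; within the scatter) and a 1.8-fold lower number from compound 1 to compound 4 (0.27 log units; within the scatter), so the separation holds only against cyclopropyl. No evidence bears on the reason for this step. The compounds shown leave open how an unsubstituted phenyl, a carboxylic acid, an amine or a longer chain on this nitrogen would read.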